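A few compounds are considered here, and "the series" means these few. Any claim that something is new, unique, unknown or untested is made for them only; others in the source may bear on it.

In an ADME assay on microsomes from liver (Homo sapiens) for metabolic stability, read by LC-MS, with NADPH named in the record, with a stated time of 60 min, tested at 1 uM, in the absence of a further agent (on this read-out higher numbers stand for a more stable compound and lower numbers for a less stable compound), compound 2 (`COc1ccc(-c2c(C)nc3c(N4CCCC4)cc(C)nn23)cc1OC`) gives > 95% as a limit of the assay, not as an exact number. Compound 1 (`COc1ccc(-c2c(C)nc3c(N4CC[C@@H](NC(C)=O)C4)cc(C)nn23)cc1OC`) gives > 95% as a limit too. All the evidence so far is therefore the limit of > 95% in this assay, at which 2 of the 2 values shown sit, and nothing finer.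

Compound 3 (`COc1ccc(-c2c(C)nc3c(N4CC[C@@H](n5cc(-c6ccccc6)nn5)C4)cc(C)nn23)cc1OC`) differs from compound 2 in one place, as 4-phenyl-1H-1,2,3-triazol-1-yl in place of hydrogen on a saturated ring carbon sets out: 4-phenyl-1H-1,2,3-triazol-1-yl in place of hydrogen on a saturated ring carbon of a five-membered non-aromatic ring with 1 nitrogen.

Going by the values given here, the one measured step that bears on this, hydrogen in place of acetamido on a saturated ring carbon, is a step that the two limits leave unreadable from compound 1 to compound 2 and offers no size to carry over. Compound 1 does show that a group on a saturated ring carbon can be present with the value still at the limit, but the entering group here is larger. In this assay, among the compounds with values here, a modest fall is therefore expected, with no measured step to fix its size. The estimated change is a number at least 10 percentage points lower from compound 2 to compound 3 (that floor lies within the scatter) and remains only an expectation. For compound 3 the estimated value is 85% with an expected range from 60% to 98% in this read-out.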

Compound 3, percent of the compound remaining: "unstable" (no number reported)
Nothing numeric was reported for compound 3; the estimate stays without a comparison.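

In this assay, going by these compounds alone, compound 3 is recorded as "unstable" (no number reported), without a number, so no step from compound 2 to compound 3 can be read. The compounds shown leave open how large the gap between compound 2 and compound 3 is, and how other groups on that saturated ring carbon would fare.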